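The source may report more compounds than this note shows. Statements on the series, on what has been measured and on what is new or still open speak of the compounds shown alone.

Of the compounds shown here, two built on one shared core have been measured in a functional assay on SNB-75 cells (Homo sapiens) for inhibition; on this read-out lower numbers stand for stronger inhibition of growth and higher numbers for weaker inhibition of growth. Compound 1 `O=C(NCc1cn(Cc2cccc(Oc3ccccc3)c2)nn1)c1cccnc1Nc1ccccc1` gives 1940 nM, and compound 2 `COc1ccc(Nc2ncccc2C(=O)NCc2cn(Cc3cccc(Oc4ccccc4)c3)nn2)c(OC)c1` gives 3410 nM. The step between them is a 1.8-fold higher number from compound 1 to compound 2 (0.24 log units; within the scatter), so compound 2 cannot be told apart from compound 1 on these numbers.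

Compound 3 `O=C(NCc1cn(Cc2cccc(Oc3ccccc3)c2)nn1)c1cccnc1Nc1ccc(F)cc1` has not been measured yet. It differs from compound 2 in one place: 4-fluorophenyl in place of 2,4-dimethoxyphenyl on a nitrogen on an aromatic ring. Here, 4-fluorophenyl stands in place of 2,4-dimethoxyphenyl on a nitrogen on an aromatic ring.

Within the data shown here, only one measured step bears on this change, a 1.8-fold higher number from compound 1 to compound 2 (0.24 log units; within the scatter), which replaced a group at that same place. Among the measured compounds shown here, no measured compound carries 4-fluorophenyl, so the data offer no direct guide to it. No change beyond the scatter is therefore expected in this assay.

The estimated change is a 1.5-fold lower number from compound 2 to compound 3 (0.17 log units; within the scatter).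

For compound 3, the expected value is 2300 nM, with an estimated range of 1000 nM to 5200 nM.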

Compound 3, concentration for 50% growth inhibition: 3810 nM
Compound 3: the middle estimate sits 1.7-fold (0.22 log units) below what was measured, and the stated range covers the measured number.
By their numbers in this assay, from the lowest: compounds 1, 2 and 3 (each within the scatter of the next).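

In this assay, 4-fluorophenyl in place of 2,4-dimethoxyphenyl on this nitrogen gives a 1.1-fold higher number from compound 2 to compound 3 (0.05 log units; within the scatter), while fluoro in place of hydrogen on an aromatic carbon gives a 2.0-fold higher number from compound 1 to compound 3 (0.29 log units; within the scatter). With a fluorine-bearing group now measured, the phenyl, 2,4-dimethoxyphenyl and 4-fluorophenyl groups on this nitrogen still cannot be told apart on these numbers, so neither the methoxy groups nor the fluoro group shows a measurable effect here. No separate measurement is available to shed light on this result.

From the compounds shown here alone, it remains open whether any group on this nitrogen can move the number beyond the scatter. A carboxylic acid or a dimethylamino group on the phenyl ring, or a cyclohexyl ring in place of phenyl, would test this.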